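The source may report more compounds than this note shows. Statements on the series, on what has been measured and on what is new or still open speak of the compounds shown alone.

Measured compounds:
compound 1, `COc1nc(C)c(CCO)c(OC)n1`: in a functional assay on HCT-116 cells (Homo sapiens) for antiproliferative activity, read by MTT assay, with a stated time of 24 h (on this read-out lower numbers stand for stronger inhibition and higher numbers for weaker inhibition), compound 1 gives > 100000 nM, which is a limit of the assay.
compound 2, `COc1nc(Cl)nc(C)c1CCO`: in this assay compound 2 gives > 100000 nM, also a limit of the assay.

Among the compounds with values here, compound 1 thus stands only at a limit in this assay; the one further value shown, that of compound 2, sits at the same limit (the limit of > 100000 nM in this assay, at which 2 of the 2 values shown sit). The step that the two limits leave unreadable from compound 1 to compound 2, chloro in place of methoxy on an aromatic carbon, cannot be read in size from two limits.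

Compound 3, `COc1nc(C)c(CCF)c(OC)n1`, differs from compound 1 by fluoro in place of hydroxy on a saturated chain carbon, two bonds along the chain from an aromatic carbon. Within the data shown here, no measured step bears on this change: the only measured step is the unreadable one, and it concerns a different place. With both measured values at the limit, no step beyond the scatter in this assay is expected; the expected step is a step that the limit leaves unreadable from compound 1 to compound 3. Compound 3 is estimated at 200000 nM, with a range of 50000 nM to 1000000 nM, most likely reported again only as a limit.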

Compound 3, half-maximal inhibitory concentration: > 100000 nM
Compound 3 was reported as a limit; the forecaster's own chance of this, stated with the estimate: 80%; the middle value lies beyond the limit too.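

In this assay compound 3 gives > 100000 nM, a limit of the assay. No step can be read between compound 1 and compound 3, since both stand at the same limit: the limit of > 100000 nM in this assay, at which 3 of the 3 values shown sit. The compounds shown leave open whether any change on the shared core brings a value inside the range of this assay.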